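Inverting both stereocentres of an azido sphinganine phosphate

The source may hold more compounds than are shown below. What is called first, only, known or untested is meant among the compounds shown, and "the series" means these compounds.

Compound 1, `CCCCCCCCCCCCCCC[C@H](O)[C@@H](COP(=O)(O)O)N=[N+]=[N-]`: 10800 nM
Compound 2, `CCCCCCCCCCCCC/C=C/[C@H](O)[C@@H](COP(=O)(O)O)N=[N+]=[N-]`: 5200 nM
Compound 3, `CCCCCCCCCCCCC/C=C/[C@@H](O)[C@H](COP(=O)(O)O)NCc1c(COP(=O)(O)O)cnc(C)c1O`: 89000 nM

Of the compounds shown here, three have been measured in an assay on isolated protein for inhibition of sphingosine-1-phosphate lyase 1 (Homo sapiens), read by fluorescence, with a stated time of 1 h; a higher number here means a weaker inhibitor, a lower number a stronger inhibitor. Compound 1 sits at the second highest of the three numbers. Its nearest neighbour is compound 2, whose number is lower by a margin beyond the scatter, and the furthest is compound 3, whose number is higher by a margin well beyond the scatter. Compound 2 and compound 3 share the chain but differ in the head group and in the drawn configuration, so their two values can only be read as they stand.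

Compound 4, `CCCCCCCCCCCCCCC[C@@H](O)[C@H](COP(=O)(O)O)N=[N+]=[N-]`, has not yet been measured in this assay. Its relation to compound 1 is the two compounds have the same atoms and bonds; at least one stereo element is drawn with a configuration in one of them and without one in the other: 2 of 3 stereo elements differ; a stereocentre at a saturated chain carbon is drawn S in compound 1 and R in compound 4; a stereocentre at a saturated chain carbon is drawn R in compound 1 and S in compound 4; nothing leaves and nothing enters. Among the compounds with values here, the only precedent for a drawn-configuration contrast is between compound 2 and compound 3, where the other drawing goes with a far higher number, though the head group also changes there. On that basis a step upward, beyond the scatter, is expected for compound 4, though with wide uncertainty. The expected step is a 2.8-fold higher number from compound 1 to compound 4 (0.44 log units; beyond the scatter). Compound 4 is estimated at 30000 nM, within a range of 8000 nM to 120000 nM.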

Compound 4, half-maximal inhibitory concentration: 25700 nM
Beside the measured number, compound 4's estimate is 1.2-fold (0.07 log units) above it, and the stated range covers the measured number.
By their numbers in this assay, from the lowest: compound 2; then compound 1; then compound 4; then compound 3.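

With atoms and bonds held the same, inverting both saturated chain carbons, one from S to R and the other from R to S, gives in this assay a 2.4-fold higher number from compound 1 to compound 4 (0.38 log units; beyond the scatter). The only earlier contrast in drawn configuration, between compound 2 and compound 3, came with a change of head group, whereas here the drawn configuration is the only difference, and it alone moves the number beyond the scatter. The step is modest, so for this azido phosphate the inversion weakens inhibition without abolishing it, although one caveat attaches to reading the step as a clean comparison of two defined configurations: the fact that one of compounds 1 and 4 is drawn with a defined configuration and the other without, at the place where they differ

On these data alone, since the two stereocentres change together, the share of each in the step remains open, and a compound inverted at only one of them would be needed to separate them. Also open, as far as these compounds go, is whether the same inversion has a similar effect on the unsaturated chain of compound 2, or when a primary amine replaces the azide or a carboxylic acid replaces the phosphate.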